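From methyl to pyridin-4-yl: half-life notes on compound 3

This account rests on a few compounds, and the source may have more. Where it says the series, first, only, none or still open, it means among the compounds named here.

Measured so far in an ADME assay, in phosphate buffer, at 28 degrees C, at pH 7.0; a higher number here means that the compound lasts longer, a lower number that the compound disappears faster 
- compound 1 (`C[C@@H](O)[C@H]1C(=O)N2C(C(=O)O)=C(C(C)(C)C)O[C@H]12`) gives 8.1 h 
- compound 2 (`C[C@H](O)[C@H]1C(=O)N2C(C(=O)O)=C(C(C)(C)C)O[C@H]12`) gives 7.1 h 

Compound 2 stands at 7.1 h in this pair, within the scatter of compound 1. Among the compounds with values here, the one measured step (a 1.1-fold lower number from compound 1 to compound 2 (0.06 log units; within the scatter)) concerns configuration alone (the fact that compounds 1 and 2 differ only in the configuration as drawn) and does not test a change of group.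

Compound 3 (`CC(C)(C)C1=C(C(=O)O)N2C(=O)[C@H]([C@@H](O)c3ccncc3)[C@H]2O1`) departs from compound 2 through a larger change (pyridin-4-yl in place of methyl on a saturated chain carbon bound to an oxygen on a saturated carbon and a saturated ring carbon) with pyridin-4-yl in place of methyl on a saturated chain carbon bound to an oxygen on a saturated carbon and a saturated ring carbon. Within the data shown here, no measured step replaces a group, so the expectation in this assay has little to rest on. A modest move to a lower number is assumed, without measured support, and the range is kept wide on both sides. The expected change is a 1.4-fold lower number from compound 2 to compound 3 (0.15 log units; within the scatter) as a working figure only. Compound 3 is estimated at 5 h with an expected range from 1.5 h to 10 h for the coming measurement.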

Compound 3, half-life: 6 h
The estimate for compound 3 lay 1.2-fold (0.08 log units) below the measured number; low and high end bracket the measured number.
By their numbers in this assay, from the lowest: compounds 3, 2 and 1 (each within the scatter of the next).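

In this assay the only change of group shown, pyridin-4-yl in place of methyl on a saturated chain carbon bound to an oxygen on a saturated carbon and a saturated ring carbon, gives a 1.2-fold lower number from compound 2 to compound 3 (0.07 log units; within the scatter) and adds a six-membered aromatic ring with 1 hetero atom at this position. Compounds 1 and 2 spoke only to configuration, whereas this step shows that the half-life stays within the scatter when a single methyl carbon gives way to a much larger aromatic group carrying a hydrogen-bond acceptor. Nothing on hand bears on why the half-life holds across this replacement.

Going by these compounds, whether phenyl, a saturated amine such as piperidin-4-yl, a carboxylic acid or a longer chain such as n-butyl would also stay within the scatter at this position remains open, since one replacement gives no trend across groups. Also open, on these data alone, are the pyridin-4-yl compound with the opposite configuration at this carbon and whether the same replacement would behave alike with a different group in place of tert-butyl on the shared core.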